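The source may hold more compounds than are shown below. What is called first, only, known or untested is meant among the compounds shown, and "the series" means these compounds.

Measured so far:
compound 1 `CCOC(=O)c1ccc(NC(=O)NCc2cocn2)cc1` gives 27600 nM in an assay on isolated protein for activation of Nicotinamide phosphoribosyltransferase (Homo sapiens); a higher number here means that more compound is needed for the effect, a lower number that less compound is needed;
compound 2 `O=C(NCc1cn[nH]c1)Nc1ccc(S(=O)(=O)c2ccccc2)cc1` gives 28 nM in this assay.

Of the two numbers, compound 1 has the highest; compound 2 is the nearest, and its lower number lies well beyond the scatter. For the measured compounds named here, no step between the two is set out here, since they differ in more than one place, so only their two values speak.

Compound 3 `CCOC(=O)c1ccc(NC(=O)NCc2cnco2)cc1` is yet to be measured. It differs from compound 1 in one place: 1,3-oxazol-5-yl in place of 1,3-oxazol-4-yl on a saturated chain carbon bound to an amide-type nitrogen. The atoms are the same, only joined differently within the five-membered ring.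

Going by the values given here, with no step between measured compounds to lean on, the expected change in this assay from compound 1 to compound 3 is small, with no direction preferred beyond the scatter, so a 1.3-fold lower number from compound 1 to compound 3 (0.10 log units; within the scatter) is the estimated step. Compound 3 is thus expected to give about 22000 nM, within a range of 6000 nM to 80000 nM.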

Compound 3, half-maximal effective concentration: 6900 nM
Compound 3: middle estimate off by 3.2-fold (0.50 log units), on the high side; low and high end bracket the measured number.
By their numbers in this assay, from the lowest: compound 2; then compound 3; then compound 1.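

In this assay, for the compounds shown here, the place on a saturated chain carbon bound to an amide-type nitrogen proves sensitive to how the five-membered ring is joined, giving the first step between compounds that differ in one place: a 4.0-fold lower number from compound 1 to compound 3 (0.60 log units; beyond the scatter) with 1,3-oxazol-5-yl in place of 1,3-oxazol-4-yl. The two groups have the same atoms and the same counts of hydrogen-bond donors and acceptors, yet the step lies beyond the scatter. Nothing available accounts for this difference.

The compounds shown leave open whether the same change would give a similar step on the core of compound 2. They also do not show how a longer chain in place of the methyl link, or an amine on that chain, would fare at this place.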